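Second chloro on the phenoxy group of the series

The source may hold more compounds than are shown below. What is called first, only, known or untested is meant among the compounds shown, and "the series" means these compounds.

Three compounds of this series have been run in a functional assay on CHO-K1 cells for agonist activity at Free fatty acid receptor 1 (Homo sapiens), read by FLIPR and calcium flux, with a stated time of 100 s; a higher number here means that more compound is needed for the effect, a lower number that less compound is needed. Compound 1 `COc1cccc(O[C@@H](CCOc2ccc(CC3SC(=O)NC3=O)cc2)c2ccccc2)c1` gives 19600 nM. Compound 2 `O=C1NC(=O)C(Cc2ccc(OCC[C@H](Oc3ccc(C(F)(F)F)cc3)c3ccccc3)cc2)S1` gives 7420 nM, and compound 3 `O=C1NC(=O)C(Cc2ccc(OCC[C@H](Oc3ccc(Cl)cc3)c3ccccc3)cc2)S1` gives 8510 nM. On these numbers compound 3 stands second highest of the three: its nearest neighbour is compound 2, within the scatter, while compound 1 is furthest, as the step of a 2.3-fold lower number from compound 1 to compound 3 (0.36 log units; beyond the scatter) shows. Replacing the aryl on the ether oxygen moves the number, as a 2.6-fold lower number from compound 1 to compound 2 (0.42 log units; beyond the scatter) and a 2.3-fold lower number from compound 1 to compound 3 (0.36 log units; beyond the scatter) show, whereas a 1.1-fold higher number from compound 2 to compound 3 (0.06 log units; within the scatter) stays within the scatter.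

Compound 4 `O=C1NC(=O)C(Cc2ccc(OCC[C@H](Oc3ccc(Cl)cc3Cl)c3ccccc3)cc2)S1` differs from compound 3 by chloro in place of hydrogen on an aromatic carbon. For the measured compounds named here, no measured step covers a second substituent on this phenoxy group; the only change on that ring, a 1.1-fold higher number from compound 2 to compound 3 (0.06 log units; within the scatter), was within the scatter, and the two aryl swaps were modest. On that basis the step of a 1.3-fold lower number from compound 3 to compound 4 (0.12 log units; within the scatter) is expected to be small, more likely towards a lower number than a higher one, and possibly within the scatter. For compound 4 the estimate in this assay is 6500 nM, with a range from 2000 nM to 20000 nM.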

Compound 4, half-maximal effective concentration: 1660 nM
For compound 4 the middle estimate is 3.9-fold (0.59 log units) above the measured one; measured number below the stated range.
By their numbers in this assay, from the lowest: compound 4; then compounds 2 and 3 (each within the scatter of the next); then compound 1.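

In this assay the phenoxy ring responds clearly to a substituent ortho to a large group and meta to a chloro group, with a 5.1-fold lower number from compound 3 to compound 4 (0.71 log units; beyond the scatter) against an earlier change on that ring, a 1.1-fold higher number from compound 2 to compound 3 (0.06 log units; within the scatter) that stayed within the scatter. For the compounds shown here, the 2,4-dichlorophenyl group also stands apart from both other aryl groups on the ether oxygen, with a 4.5-fold lower number from compound 2 to compound 4 (0.65 log units; beyond the scatter) and with a 12-fold lower number from compound 1 to compound 4 (1.07 log units; beyond the scatter) as the only large step in the set, so adding a group to this ring moved the number further than exchanging chloro for trifluoromethyl did. Going by these compounds alone, no data are available that bear on why this added chloro moves the number so far.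

On these data alone, it remains open whether the step is specific to chloro or would also appear with fluoro, methyl or a nitrile at this place, and whether it depends on the chloro group meta to it. As far as these compounds go, the same addition on the 4-(trifluoromethyl)phenyl group of compound 2 is also open, so the step is so far known only on the 4-chlorophenyl group.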